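The compounds below may be only part of what the source reports. "The series", "measured", "known", "first", "only" and "open" are said of these compounds alone.

Going by the values given here, in an ADME assay on S9 fraction from liver (Homo sapiens) for metabolic stability, with a stated time of 1 h (a higher number here means that more of the compound is left, a lower number that less of the compound is left), three compounds have numbers so far. Compound 1 (`N#Cc1cnc(NCc2ccccc2C(F)(F)F)cc1N[C@H]1CC[C@@H](O)CC1`) gives 0% and compound 3 (`N#Cc1cnc(NCc2ccccc2C(F)(F)F)cc1N[C@H]1C[C@H](C(N)=O)C1`) gives 68% of the compound left. Compound 2 (`N#Cc1cnc(NCc2cnccc2C(F)(F)F)cc1N[C@H]1CC[C@H](O)CC1`) gives 30% and is the second highest of the three, with both gaps beyond the scatter.

The next entry is compound 4 (`N#Cc1cnc(NCc2cnccc2C(F)(F)F)cc1N[C@H]1CC[C@@H](C(N)=O)CC1`), which keeps the core of compound 2 and changes only the group on the nitrogen. The difference is 4-carbamoylcyclohexyl in place of 4-hydroxycyclohexyl on a nitrogen on an aromatic ring and reads as 4-carbamoylcyclohexyl in place of 4-hydroxycyclohexyl on a nitrogen on an aromatic ring.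

Among the compounds with values here, one measured step bears on this, namely a number 68 percentage points higher from compound 1 to compound 3 (beyond the scatter) with 3-carbamoylcyclobutyl in place of 4-hydroxycyclohexyl. That step is large, but it also changes the ring, whereas compound 4 keeps a six-membered non-aromatic ring of carbon only. Within the data shown here, the aromatic part of compound 2 also differs from that of compound 1, and no measured pair isolates the carbamoyl group on a six-membered ring. Only part of that rise is therefore expected to carry over.

The expected step is a number 25 percentage points higher from compound 2 to compound 4 (beyond the scatter) as a rise of moderate size. For compound 4 the estimated value is 55% with an expected range from 30% to 80% in this assay.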

Compound 4, percent of the compound remaining: 90%
The estimate for compound 4 lay 35 percentage points below the measured number; the measured number lies above the stated range.
By their numbers in this assay, from the lowest: compound 1; then compound 2; then compound 3; then compound 4.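

In this assay, 4-carbamoylcyclohexyl in place of 4-hydroxycyclohexyl on a nitrogen on an aromatic ring gives a number 60 percentage points higher from compound 2 to compound 4 (beyond the scatter), a large step with the six-membered non-aromatic ring of carbon only kept and nothing else in the structure changed. The earlier step, a number 68 percentage points higher from compound 1 to compound 3 (beyond the scatter), replaced the ring as well as the group on it, so it could not show that a large rise at this position is possible without any change of ring size; the two steps now point the same way on two different aromatic parts, and neither goes against the other. No measurement shown here accounts for the size of the rise at this position.

Still open, from the compounds shown here alone, is whether the rise belongs to the carbamoyl group itself or would also appear with a carboxylic acid, a primary amine or an N-methyl amide at the same place on the ring. Also open, going by these compounds, is how large the same change would be on the core of compound 1, which carries a different aromatic part, and how the other stereoisomer of 4-carbamoylcyclohexyl would behave.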